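This account rests on a few compounds, and the source may have more. Where it says the series, first, only, none or still open, it means among the compounds named here.

Working notes on the series. Three compounds have been run in an assay on isolated protein for inhibition of sterol O-acyltransferase 1 (Mus musculus), tested at 0.1 uM; a lower number here means less inhibition, a higher number more inhibition at the concentration tested (going by the name of the read-out). Compound 1 `CCCCCCCCCCCCn1nnc(C(C(=O)Nc2ncccc2C)c2ccccc2)n1` gives 4% in this assay. Compound 2 `CCCCCCCCCCCCn1nnc(C(C(=O)Nc2c(OC)cc(OC)cc2OC)c2ccc(OC)cc2)n1` gives 61%. Compound 3 `CCCCCCCCCCCCn1nnc(C(C(=O)Nc2c(C(C)C)cccc2C(C)C)c2nnn[nH]2)n1` gives 8%, which is the second highest of the three numbers: compound 1 lies closest, with a number a few points lower that sits within the usual scatter, and compound 2 lies furthest, with a number well above it that sits beyond the scatter. Compound 4 `CCCCCCCCCCCCn1nnc(CC(=O)Nc2c(C(C)C)cccc2C(C)C)n1` has not yet been measured. It differs from compound 3 in one place: hydrogen in place of 1H-tetrazol-5-yl on a saturated chain carbon bound to an aromatic carbon and a carbonyl carbon. For the measured compounds named here, no step between measured compounds covers this change, so its size has to be judged from the three numbers alone, which offer no direct parallel. The step from compound 3 to compound 4 is expected to be small, at most slightly upward, roughly a number 7 percentage points higher from compound 3 to compound 4 (within the scatter), and may not rise beyond the scatter. Compound 4 is therefore estimated at 15% in this assay, with a range from 0% to 40%.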

Compound 4, a percentage reported as inhibition, at one concentration (the size of the read-out at that concentration, not a potency): 91%
Compound 4: the middle estimate sits 76 percentage points below what was measured, outside the stated range (above it).
By their numbers in this assay, from the lowest: compounds 1 and 3 (each within the scatter of the next); then compound 2; then compound 4.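

In this assay, for the compounds shown here, hydrogen in place of 1H-tetrazol-5-yl on a saturated chain carbon bound to an aromatic carbon and a carbonyl carbon gives a number 83 percentage points higher from compound 3 to compound 4 (beyond the scatter), the first single-place reading at this position, and it shows that the read-out is highly sensitive to this change. Compound 4 reaches 91% with only hydrogen on this carbon, so a high number in this assay does not require a ring there, although compounds 1, 2 and 3 all carry one. No measurement available here accounts for the size of this step.

The compounds shown leave open whether this step is specific to 1H-tetrazol-5-yl or would also appear with any other group on this carbon. A methyl group or a carboxylic acid at this position, on the otherwise unchanged structure of compound 4, would separate those two readings.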